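Halogen swap on the aryl group of compound 1

The source may report more compounds than this note shows. Statements on the series, on what has been measured and on what is new or still open speak of the compounds shown alone.

Within the data shown here, in a functional assay on HepG2 cells (Homo sapiens) for cytotoxicity, read by MTT assay, with a stated time of 72 h (on this read-out higher numbers stand for weaker inhibition and lower numbers for stronger inhibition), compound 1 (`CNC(=O)c1cc(Oc2ccc(C3=NNC(c4cccc(Br)c4)C3)cc2)ccn1`) gives 1850 nM, the lower of the two numbers so far, while compound 2 (`CNC(=O)c1cc(Oc2ccc(C3=NNC(c4cc(OC)c(OC)c(OC)c4)C3)cc2)ccn1`) gives 24300 nM. Compound 3 (`CNC(=O)c1cc(Oc2ccc(C3=NNC(c4ccc(F)cc4Cl)C3)cc2)ccn1`) carries 2-chloro-4-fluorophenyl in place of 3-bromophenyl on a saturated ring carbon. Among the measured compounds shown here, no measured pair isolates this change, so the expectation is weakly founded. The new group is also a halogen-bearing phenyl, so only a small rise in this assay, near the scatter, is expected: a 1.6-fold higher number from compound 1 to compound 3 (0.21 log units; within the scatter). For compound 3 the estimated value is 3000 nM, with an expected range of 1000 nM to 9000 nM.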

Compound 3, half-maximal inhibitory concentration: 11500 nM
Compound 3: middle estimate off by 3.8-fold (0.58 log units), on the low side; measured number above the stated range.
By their numbers in this assay, from the lowest: compound 1; then compound 3; then compound 2.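

In this assay, this saturated ring carbon does not treat halogen-bearing phenyl groups alike: 2-chloro-4-fluorophenyl in place of 3-bromophenyl gives a 6.2-fold higher number from compound 1 to compound 3 (0.79 log units; beyond the scatter). Carrying halogen on the phenyl is therefore not enough to keep the number of compound 1 at this position. No measurement at hand accounts for this step.

Going by these compounds, the change swaps both the halogens and where they sit on the phenyl, so the contribution of each remains open. A 3-chlorophenyl or 3-aminophenyl group at this carbon would test the halogen requirement more directly.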